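This account rests on a few compounds, and the source may have more. Where it says the series, first, only, none or still open, it means among the compounds named here.

Of the compounds shown here, two have been tested so far: compound 1 (`O=C(CCC(F)(F)C(F)(F)C(F)(F)C(F)(F)C(F)(F)C(F)(F)C(F)(F)C(F)(F)F)NCCCCCCCCCN[C@@H]1[C@H](O)[C@@H](O)[C@H](O)[C@H]2COC(=O)N21`) and compound 2 (`O=C(CCC(F)(F)C(F)(F)C(F)(F)C(F)(F)C(F)(F)C(F)(F)F)NCCCCCCCCCN[C@@H]1[C@H](O)[C@@H](O)[C@@H](O)[C@H]2COC(=O)N21`). Among the compounds with values here, in a functional assay on HBL-100 cells (Homo sapiens) for inhibition, read by sulforhodamine B assay, with a stated time of 48 h (on this read-out higher numbers stand for weaker inhibition of growth and lower numbers for stronger inhibition of growth), compound 2 gives 16000 nM as the only true number available. Compound 1 gives > 100000 nM in this assay and this is a limit of the assay, not a number. On these data alone, compound 3 (`O=C(CCC(F)(F)C(F)(F)C(F)(F)C(F)(F)C(F)(F)C(F)(F)C(F)(F)C(F)(F)F)NCCCCCCCCCN[C@@H]1[C@H](O)[C@@H](O)[C@@H](O)[C@H]2COC(=O)N21`) is still untested. Compared with compound 2, it has 1,1,2,2,2-pentafluoroethyl in place of fluoro on a saturated chain carbon bound to two fluorine atoms and a saturated chain carbon. Within the data shown here, no measured step shows what such a change does, so the value of compound 2 (16000 nM) is the only anchor and no step beyond the usual scatter is expected in this assay for this change. The estimated step (a 1.3-fold higher number from compound 2 to compound 3 (0.10 log units; within the scatter)) is therefore small. For compound 3 the expected value is 20000 nM with a wide estimated range (from 6000 nM to 70000 nM).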

Compound 3, concentration for 50% growth inhibition: > 100000 nM
Compound 3: only a limit was reported (the forecaster's own chance of this, stated with the estimate: 25%); middle value at least 5.0-fold (0.69 log units) from the limit.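

In this assay, within the data shown here, putting 1,1,2,2,2-pentafluoroethyl in place of fluoro on a saturated chain carbon bound to two fluorine atoms and a saturated chain carbon gives an at least 6.2-fold higher number from compound 2 to compound 3 (0.79 log units; beyond the scatter), so this change weakens growth inhibition beyond the usual scatter, which the earlier compounds could not show. The reading for compound 3 is a limit of the assay and not a number, so this step has only a lower bound, and the step between compound 1 and compound 3 cannot be read, because both sit at the same limit: the limit of > 100000 nM in this assay, at which 2 of the 3 values shown sit. The stereocentre therefore shows no readable effect on this longer chain, and that pair offers only one comparison: the fact that compounds 1 and 3 differ only in the configuration as drawn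

Open, on these data alone, is what a plain hydrocarbon chain at this place would give, and whether a carboxylic acid at its end would restore growth inhibition. Also open, as far as these compounds go, is what the same stereocentre does with the shorter chain of compound 2.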